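The source may hold more compounds than are shown below. What is called first, only, known or untested is meant among the compounds shown, and "the series" means these compounds.

Compound 1 `N=c1c2cc(-c3ccccc3)n(-c3ccccc3)c2[nH]c(=S)n1N` gives 23% in a functional assay on the whole organism for inhibition, with Rattus norvegicus as the target, read by ELISA, with stated times of 30 min and 6 h, at a dose of 30 mg/kg by the oral route; a lower number here means less inhibition, a higher number more inhibition at the dose given (going by the name of the read-out). Going by the values given here, compound 2 `N=c1c2cc(-c3ccc(Cl)cc3)n(-c3ccccc3)c2[nH]c(=S)n1N`, which carries chloro in place of hydrogen on an aromatic carbon, gives 0% in this assay, and this is the lowest of the two numbers measured so far; the step of a number 23 percentage points lower from compound 1 to compound 2 (beyond the scatter) is modest but lies beyond the scatter. Compound 3 `Cc1ccc(-c2cc3c(=N)n(N)c(=S)[nH]c3n2-c2ccccc2)cc1` has not yet been measured. It differs from compound 2 by methyl in place of chloro on an aromatic carbon. Among the compounds with values here, only one measured step bears on this change, the one from compound 1 to compound 2, in which chloro lowered the number by a modest amount. Nothing measured tells directly how methyl behaves at this place: compound 1 shows what hydrogen gives there and compound 2 what chloro gives. An expectation for compound 3 can therefore only be placed between those two readings. Compound 3 is estimated at 10% in this assay, within a range of 0% to 30%. The expected step of a number 10 percentage points higher from compound 2 to compound 3 (within the scatter) would be a small rise, close to the scatter, and the measurement will show whether it holds.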

Compound 3, a percentage reported as inhibition, in the whole organism at one dose (the size of the read-out at that dose, not a potency): 0%
Compound 3: the middle estimate sits 10 percentage points above what was measured; low and high end bracket the measured number.
By their numbers in this assay, from the lowest: compounds 2 and 3 (each within the scatter of the next); then compound 1.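

In this assay, methyl in place of chloro on the aromatic carbon para to a large group gives no change at the digits printed from compound 2 to compound 3 (within the scatter), so at this dose the two groups cannot be told apart at this place. Methyl in place of hydrogen gives a number 23 percentage points lower from compound 1 to compound 3 (beyond the scatter), which matches the step seen with chloro and shows that the lower reading is not confined to the chlorine-bearing 4-chlorophenyl compound: both substituents tried here, in compound 2 and compound 3, stand beyond the scatter below the unsubstituted phenyl of compound 1. Nothing available explains why either group goes with the lower number, or what the two groups might have in common at this place.

As far as these compounds go, whether any other group at this place, such as an amine, a carboxylic acid or a longer chain like propyl, would keep the reading of compound 1, lift it, or also lower it remains open. Also open, from the compounds shown here alone, is whether compound 2 and compound 3 would separate from each other at a different dose, since a single dose gives the size of the read-out and not a potency.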